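Compound 3 to compound 4: acetyl on an oxygen

The source may report more compounds than this note shows. Statements on the series, on what has been measured and on what is new or still open speak of the compounds shown alone.

Measured in a functional assay on HeLa cells (Homo sapiens) for cytotoxicity, read by XTT assay, with a stated time of 72 h; a higher number here means a weaker inhibitor, a lower number a stronger inhibitor:
Compound 1 `CCn1ccc2cc(C(O)c3cc(OC)c(OC)c(OC)c3)ccc21`: > 1000 nM
Compound 2 `CCn1ccc2cc(C(OC(C)=O)c3cc(OC)c(OC)c(OC)c3)ccc21`: > 1000 nM
Compound 3 `CCn1ccc2cc(/C(=N\O)c3cc(OC)c(OC)c(OC)c3)ccc21`: > 1000 nM

As the limit of > 1000 nM in this assay, at which 3 of the 3 values shown sit, shows, all three entries are limits of the assay and not numbers. Compound 3 therefore stands only at a limit. Compound 4 `CCn1ccc2cc(/C(=N\OC(C)=O)c3cc(OC)c(OC)c(OC)c3)ccc21` differs from it by hydroxy to acetoxy (acetyl in place of hydrogen on an oxygen). The nearest measured change, acetyl in place of hydrogen on an oxygen on a saturated carbon, is a step that the two limits leave unreadable from compound 1 to compound 2. It gives no size or direction to carry over, so no clear change is expected in this assay. The expected step is a step that the limit leaves unreadable from compound 3 to compound 4, and it is only a loose estimate. For compound 4 the estimated value is 2500 nM, with an expected range of 500 nM to 10000 nM.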

Compound 4, half-maximal inhibitory concentration: > 1000 nM
Compound 4 was reported as a limit; the forecaster's own chance of this, stated with the estimate: 80%; the middle value lies beyond the limit too.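

In this assay, among these compounds, compound 3 and compound 4 are both limits and not numbers, and no step between them can be read. The compounds shown leave open how far each lies beyond that limit, and whether acetyl on the oxygen changes anything.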